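This account rests on a few compounds, and the source may have more. Where it says the series, first, only, none or still open, it means among the compounds named here.

Measured so far:
compound 1, `NC(=S)n1ccc2c(OCCCCCOc3ccc(Cl)cc3)cccc21`: 24700 nM
compound 2, `O=C(NC(=S)N1CCc2c(OCCCCCOc3ccc(Cl)cc3)cccc21)Oc1ccccc1`: > 50000 nM

Compound 1 gives 24700 nM in an ADME assay on Huh-7 cells (Homo sapiens) for cytotoxicity; a lower number here means that less compound is tolerated, a higher number that more compound is tolerated. For compound 2, this assay reports only a limit, > 50000 nM, so where compound 2 stands is known only as far as the limit of > 50000 nM in this assay, at which 1 of the 2 values shown sits, and no finer comparison with compound 1 can be drawn from that. Compound 3, `O=C(NC(=S)N1CCc2c(OCCCCCOc3ccc(Cl)cc3)cccc21)c1ccc([N+](=O)[O-])cc1`, is not yet measured. It differs from compound 2 in one place: 4-nitrophenyl in place of phenoxy on a carbonyl carbon. Among the measured compounds shown here, no measured step between compounds links a change of this kind to this assay, so the expectation rests only on the position of compound 2 at the bound. The step of an at least 1.1-fold lower number from compound 2 to compound 3 (0.04 log units; that floor lies within the scatter) is expected to be none beyond the scatter, with a real chance that a limit rather than a number is reported again. Compound 3 is accordingly estimated at 45000 nM, within a range from 15000 nM to 100000 nM.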

Compound 3, half-maximal cytotoxic concentration: 13600 nM
Compound 3: middle estimate off by 3.3-fold (0.52 log units), on the high side; the measured number lies below the stated range.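

On a carbonyl carbon whose other neighbour is an amide-type nitrogen, the group carried there makes a readable difference in this assay: 4-nitrophenyl in place of phenoxy gives an at least 3.6-fold lower number from compound 2 to compound 3 (0.56 log units; beyond the scatter). Among the compounds shown here, this is the first measured step at this place, so the place can no longer be treated as indifferent to this read-out, although one pair shows only this single change and supports no wider pattern. The full size of the step stays unknown because compound 2 carries only a limit, not a number: the limit of > 50000 nM in this assay, at which 1 of the 3 values shown sits.

The change swaps two things at once, the phenoxy oxygen on the carbonyl carbon and the nitro group on the ring, and the compounds shown do not separate them; a plain phenyl on the same carbonyl carbon would stand between compound 2 and compound 3 and divide the step into its two parts. Also open, going by these compounds, is whether the step would persist with an amine on that carbonyl carbon, or with a shorter chain linking the chlorophenoxy group to the shared core.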